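From 4-bromophenyl to 4-methylphenyl: working notes

The source may report more compounds than this note shows. Statements on the series, on what has been measured and on what is new or still open speak of the compounds shown alone.

In a functional assay on NCI-H460 cells (Homo sapiens) for inhibition, read by sulforhodamine B assay, with a stated time of 48 h (a lower number here means a stronger inhibitor of growth, a higher number a weaker inhibitor of growth), compound 3 (`CC(C)(C)NCc1c(C(=O)O)nn(-c2ccc(Cl)cc2)c1-c1ccc(Br)cc1`) gives > 542000 nM, which is a limit of the assay and not a number. Compound 2 (`CC(C)(C)NCc1c(C(=O)O)nn(-c2ccc(Cl)cc2)c1-c1ccc(F)cc1`) gives > 623000 nM, also a limit. The next change leads to compound 4 (`Cc1ccc(-c2c(CNC(C)(C)C)c(C(=O)O)nn2-c2ccc(Cl)cc2)cc1`): methyl in place of bromo on an aromatic carbon, para to a large group.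

Going by the values given here, the one measured step at this position, bromo in place of fluoro, is a step that the two limits leave unreadable from compound 2 to compound 3, so it gives no size to carry over. Compound 1 (`CCOC(=O)c1nn(-c2ccc(Cl)cc2)c(-c2ccc(C)cc2)c1CNC(C)(C)C`) also carries the 4-methylphenyl and gives 277000 nM; > 542000 nM (2 entries). With no readable step to build on, no step beyond the scatter is expected in this assay. The expected change is a step that the limit leaves unreadable from compound 3 to compound 4, and it will probably be unreadable if compound 4 also returns a limit. Compound 4 is expected at 550000 nM, with an estimated range of 250000 nM to 700000 nM.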

Compound 4, concentration for 50% growth inhibition: > 629000 nM
Compound 4 gave a limit, no number (the forecaster's own chance of this, stated with the estimate: 75%); middle value at least 1.1-fold (0.05 log units) from the limit.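

In this assay compound 4 gives > 629000 nM, a limit and not a number, so the steps from compound 3 and from compound 2 to compound 4 cannot be read. The compounds shown leave open whether fluoro, bromo and methyl at this position differ at all in this assay.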